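Swapping the cyanoguanidine tail for a thiourea on a pyridazinone

The compounds below may be only part of what the source reports. "The series", "measured", "known", "first", "only" and "open" are said of these compounds alone.

For the measured compounds named here, compound 1, `CN(C)/C(=N/CCCCn1nc(-c2ccccc2)ccc1=O)NC#N`, has the higher of the two numbers measured so far in a functional assay on the whole organism with Rattus norvegicus as the target, at a dose of 100 mg/kg; a lower number here means less inhibition, a higher number more inhibition at the dose given (going by the name of the read-out). In this assay compound 1 gives 80.7%, while compound 2, `O=c1ccc(-c2ccccc2)nn1CCCC/N=C(\S)Nc1ccc(S(=O)(=O)O)cc1`, gives 25.1%, a gap that lies beyond the usual scatter of repeated measurements. Going by the values given here, compound 2 differs from compound 1 in more than one place, so the comparison between them shows only that the two values differ, not which change is responsible.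

Compound 3, `CC(C)(C)/N=C(\S)NCCCCn1nc(-c2ccccc2)ccc1=O`, has not yet been measured. It differs from compound 1 by a group of 8 heavy atoms (5 carbon, 2 nitrogen, 1 sulfur; no ring) in place of a group of 8 heavy atoms (4 carbon, 4 nitrogen; no ring), on a saturated chain carbon, four bonds along the chain from an aromatic nitrogen. The leaving group carries the triple bond; the entering group brings a sulfur atom and one more hydrogen-bond donor.

Among the compounds with values here, no single-change step between measured compounds exists here, so the expectation rests only on the two values shown. The lower value of compound 2 suggests that compound 3 may fall below compound 1, but the loss is expected to be moderate rather than complete. The expected step of a number 20.7 percentage points lower from compound 1 to compound 3 (beyond the scatter) is a decrease beyond the scatter. Compound 3 is estimated to give 60%, within the range 30% to 88%.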

Compound 3, a percentage reported as inhibition, in the whole organism at one dose (the size of the read-out at that dose, not a potency): 33.6%
The estimate for compound 3 lay 26.4 percentage points above the measured number, and the stated range covers the measured number.
By their numbers in this assay, from the lowest: compounds 2 and 3 (each within the scatter of the next); then compound 1.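

For the compounds shown here, this is the first comparison in the piece in which only one place changes: the tail on a saturated chain carbon, four bonds along the chain from an aromatic nitrogen, while the rest of the molecule stays the same. In this assay this exchange gives a number 47.1 percentage points lower from compound 1 to compound 3 (beyond the scatter), even though the group that leaves and the group that enters have the same number of heavy atoms, so the read-out depends on what this tail is made of and not merely on a tail of that size being present. No measurement of any property of these groups accompanies the step, so the result shows what changed and not why.

The exchange removes the triple bond, brings in sulfur and adds a hydrogen-bond donor all at once, so the compounds shown leave open which of these differences accounts for the loss. A urea with oxygen in place of the sulfur, a cyanoguanidine ending in a tert-butyl amine, or either tail on a longer chain would each test one of these differences separately.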